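The source may hold more compounds than are shown below. What is called first, only, known or untested is meant among the compounds shown, and "the series" means these compounds.

Working notes on the series. In a functional assay on A2780 cells (Homo sapiens) for inhibition, with a stated time of 72 h (a higher number here means a weaker inhibitor, a lower number a stronger inhibitor), compound 1 (`CC1(C)CCNc2ccc(NC(=S)Nc3ccc([N+](=O)[O-])cc3)cc21`) gives 7100 nM as its half-maximal inhibitory concentration, and compound 2 (`CC1(C)CCNc2ccc(NC(=S)Nc3ccc(C(F)(F)F)cc3)cc21`) gives 6000 nM on the same read-out. On these two numbers compound 2 stands level with compound 1, since the two lie within the scatter of each other.

The next compound is compound 3 (`CC1(C)CCNc2ccc(NC(=S)Nc3ccc(OC(F)(F)F)cc3)cc21`), with trifluoromethoxy in place of trifluoromethyl on an aromatic carbon, para to a large group (trifluoromethoxy in place of trifluoromethyl on an aromatic carbon).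

Going by the values given here, only one measured step bears on this change: a 1.2-fold lower number from compound 1 to compound 2 (0.07 log units; within the scatter) for trifluoromethyl in place of nitro on an aromatic carbon. Among the compounds with values here, no measured step involves trifluoromethoxy itself, so the evidence is thin. With that single exchange on the shared core giving no shift beyond the scatter, none is expected here either, in either direction.

The expected size of the change is no change at the digits printed from compound 2 to compound 3 (within the scatter) on this estimate. Compound 3 is estimated at 6000 nM in this assay with an expected range of 2800 nM to 12000 nM for repeated measurements.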

Compound 3, half-maximal inhibitory concentration: 7100 nM
For compound 3 the middle estimate is 1.2-fold (0.07 log units) below the measured one, within the range that was stated.
By their numbers in this assay, from the lowest: compounds 2, 1 and 3 (each within the scatter of the next).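

In this assay, the exchange of trifluoromethyl for trifluoromethoxy gives a 1.2-fold higher number from compound 2 to compound 3 (0.07 log units; within the scatter), and the exchange of nitro for trifluoromethoxy gives no change at the digits printed from compound 1 to compound 3 (within the scatter). Where the earlier pair showed only that nitro and trifluoromethyl stand level, this place on the aromatic carbon, para to a large group, now holds three different groups with no step beyond the scatter, and that includes a group bringing in an oxygen and a hydrogen-bond acceptor that trifluoromethyl does not have. No measurement at hand explains why the number stays level across these three groups.

The compounds shown leave open whether this level reading extends to groups of another kind at the same place, such as an amine, a carboxylic acid or a longer alkyl chain, since the three groups here may not span the range that could shift the number. They also leave open whether any change to the shared core, rather than to this substituent, could move the number beyond the scatter.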